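Ureido in Place of Carbamoyl on a Potent Desaturase Inhibitor

The source may hold more compounds than are shown below. What is called first, only, known or untested is meant among the compounds shown, and "the series" means these compounds.

Compound 1 `NC(=O)c1cnc(N2CCC(Oc3ccccc3C(F)(F)F)CC2)s1` gives 3 nM in an assay on microsomes from liver (strain Wistar) for inhibition of acyl-CoA desaturase 1 (Rattus norvegicus), read by HPLC, with stated times of 1 h and 60 min (on this read-out lower numbers stand for stronger inhibition and higher numbers for weaker inhibition), the lowest number among the three measured compounds. Compound 2 `NC(=O)c1csc(N2CCC(Oc3ccccc3C(F)(F)F)CC2)n1` gives 676 nM and compound 3 `NC(=O)c1nc(N2CCC(Oc3ccccc3C(F)(F)F)CC2)no1` gives 1630 nM in this assay; the steps of a 230-fold higher number from compound 1 to compound 2 (2.35 log units; beyond the scatter) and a 540-fold higher number from compound 1 to compound 3 (2.74 log units; beyond the scatter) are both large, while a 2.4-fold higher number from compound 2 to compound 3 (0.38 log units; beyond the scatter) is modest. Compound 4 `NC(=O)Nc1cnc(N2CCC(Oc3ccccc3C(F)(F)F)CC2)s1` differs from compound 1 by ureido in place of carbamoyl on an aromatic carbon. For the measured compounds named here, none of the measured steps touches this group: all three exchange the ring that carries the carbamoyl, so they do not bear on the change. The expectation therefore rests on compound 1 alone, anchored at 3 nM. Compound 4 is expected to show a 2.7-fold higher number from compound 1 to compound 4 (0.43 log units; beyond the scatter), a step not far beyond the scatter. The estimated value of compound 4 is 8 nM, within 2 nM to 40 nM.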

Compound 4, half-maximal inhibitory concentration: 150 nM
For compound 4 the middle estimate is 19-fold (1.27 log units) below the measured one, outside the stated range (above it).
By their numbers in this assay, from the lowest: compound 1; then compound 4; then compound 2; then compound 3.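

For the compounds shown here, with the ring held constant, this is the first change to the group on the aromatic carbon next to the ring sulfur. In this assay, ureido in place of carbamoyl gives a 50-fold higher number from compound 1 to compound 4 (1.70 log units; beyond the scatter), so this position does not accept the exchange without a large loss. No measurement given here accounts for this step. The compounds shown leave open whether an acetylamino group or a carboxylic acid on the same carbon would stay closer to compound 1, and whether ureido would produce a similar step on the rings of compound 2 and compound 3.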